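The compounds below may be only part of what the source reports. "The series", "measured", "known", "first", "only" and "open" are said of these compounds alone.

Measured in a functional assay on NPC-TW01 cells (Homo sapiens) for antiproliferative activity, read by MTT assay, with a stated time of 72 h; on this read-out lower numbers stand for stronger inhibition of growth and higher numbers for weaker inhibition of growth:

Compound 1, `O=C(COc1c(-c2ccccc2)oc2ccccc2c1=O)Nc1ccc(F)cc1`: 9500 nM
Compound 2, `COc1ccc(NC(=O)COc2c(-c3ccccc3)oc3ccccc3c2=O)cc1`: 5480 nM
Compound 3, `O=C(COc1ccc2c(=O)c(-c3ccccc3)coc2c1)Nc1ccc(F)cc1`: 550 nM

Compound 1 and compound 2 share one core and differ only by methoxy in place of fluoro on an aromatic carbon. That step reads a 1.7-fold lower number from compound 1 to compound 2 (0.24 log units; within the scatter), so the two numbers cannot be ordered with confidence. Compound 3 is built from the same atoms as compound 1, joined differently; the difference between the two cores is not broken down here. In this assay compound 3 gives the lowest number of the three, with compound 2 a tenth-of-a-log-unit-scale gap away beyond the scatter and compound 1 further still.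

Compound 4, `COc1ccc(NC(=O)COc2ccc3c(=O)c(-c4ccccc4)coc3c2)cc1`, is not yet measured. It differs from compound 3 by methoxy in place of fluoro on an aromatic carbon, the same change as from compound 1 to compound 2, at the same place. For the measured compounds named here, only that one precedent exists, and it fell within the scatter, so the expected step is a 1.4-fold lower number from compound 3 to compound 4 (0.14 log units; within the scatter), of about the size seen in a 1.7-fold lower number from compound 1 to compound 2 (0.24 log units; within the scatter). On that basis compound 4 is estimated at 400 nM, expected to lie between 150 nM and 1200 nM.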

Compound 4, concentration for 50% growth inhibition: 6700 nM
The estimate for compound 4 lay 17-fold (1.22 log units) below the measured number; the measured number lies above the stated range.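

In this assay, methoxy in place of fluoro now gives a 12-fold higher number from compound 3 to compound 4 (1.09 log units; beyond the scatter), a large step towards weaker inhibition of growth. Set beside the earlier step, the same change does not carry from one core to the other at one size: the same change on two cores in this assay, a 1.7-fold lower number (0.24 log units; within the scatter) from compound 1 to compound 2 and a 12-fold higher number (1.09 log units; beyond the scatter) from compound 3 to compound 4, 21-fold (1.32 log units) apart, beyond the scatter of two such steps

This shows that, for these two pairs, the effect of the change depends on the core it sits on, so a step read on one core is a poor guide to the other. With one pair per core, it does not show what in the cores makes the difference, or how the change would behave on any further core.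

The compounds shown hold only fluoro and methoxy on the anilide ring, so it stays open whether the weaker growth inhibition on this core is particular to methoxy or would also appear with chloro, hydroxy or an amine at that place. Also open, from the compounds shown here alone, is how a longer chain between the ether oxygen and the amide would alter the step on either core.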